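Swapping the Aryl Ring on the Shared Core

A few compounds are considered here, and "the series" means these few. Any claim that something is new, unique, unknown or untested is made for them only; others in the source may bear on it.

Measured compounds:
compound 1 `Cc1cc(NC(=O)Cn2nnc(-c3cccnc3)n2)n(C2CCCCC2)n1`: 96%
compound 2 `Cc1cc(NC(=O)Cn2nnc(-c3ccccn3)n2)n(C2CCCCC2)n1`: 81%
compound 3 `Cc1cc(NC(=O)Cn2nnc(-c3ccnc(F)c3)n2)n(C2CCCCC2)n1`: 95%

All three were tested in an assay on HEK293 cells for activation of Kir3.1/Kir3.2 (Homo sapiens), read by thallium flux; a higher number here means a larger maximal response, a lower number a smaller maximal response. Compound 3 stands second highest of the three: against compound 1 the gap is within the scatter (a number 1 percentage points lower from compound 1 to compound 3 (within the scatter)), against compound 2 it is beyond it (a number 14 percentage points higher from compound 2 to compound 3 (beyond the scatter)). Compound 4 `Cc1cccc(-c2nnn(CC(=O)Nc3cc(C)nn3C3CCCCC3)n2)c1` differs from compound 3 by 3-methylphenyl in place of 2-fluoropyridin-4-yl on an aromatic carbon. For the measured compounds named here, no measured step exchanges the six-membered aromatic ring with 1 hetero atom for a ring of carbon only, so the earlier steps bear only loosely on this one; the largest ring swap seen, a number 15 percentage points lower from compound 1 to compound 2 (beyond the scatter), was modest. Compound 4 is therefore expected to land close to compound 3, with a step of a number 5 percentage points lower from compound 3 to compound 4 (within the scatter). The estimate for compound 4 is 90%, ranging from 75% to 102%.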

Compound 4, largest response reached (Emax), in percent of the reference or control that the assay uses: 93%
Estimate against measurement, compound 4: 3 percentage points below, within the range that was stated.
By their numbers in this assay, from the lowest: compound 2; then compounds 4, 3 and 1 (each within the scatter of the next).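

In this assay, 3-methylphenyl, a ring of carbon only, holds the response at this position on the five-membered aromatic ring: a number 2 percentage points lower from compound 3 to compound 4 (within the scatter) and a number 3 percentage points lower from compound 1 to compound 4 (within the scatter), so neither a ring nitrogen nor fluorine is required at the level seen here. For the compounds shown here, compound 2 remains apart, with a number 12 percentage points higher from compound 2 to compound 4 (beyond the scatter), and pyridin-2-yl is the only group of the four whose steps to all the others lie beyond the scatter. Nothing measured here explains why pyridin-2-yl differs from the other groups. On these data alone, whether a saturated ring such as cyclohexyl, an amine or a carboxylic acid would hold the response at this position stays open.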